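A 6-carboxy-1H-indol-3-yl group replaces the group on compound 2

The source may report more compounds than this note shows. Statements on the series, on what has been measured and on what is new or still open speak of the compounds shown alone.

In an ADME assay on MDCK-II cells (Canis lupus familiaris) for permeability (a lower number here means that the compound crosses the layer more slowly, a higher number that the compound crosses the layer faster), compound 1 `OC[C@@H](O[C@H]1CCCN(Cc2ncc[nH]2)[C@H]1c1ccccc1)c1cc(Cl)cc(Cl)c1` gives 19 10^-6 cm/s and compound 2 `OC[C@@H](O[C@H]1CCCN(Cc2cccc3nonc23)[C@H]1c1ccccc1)c1cc(Cl)cc(Cl)c1` gives 11 10^-6 cm/s so these two compounds stand within the scatter of each other. Among the measured compounds shown here, the one measured step is a 1.7-fold lower number from compound 1 to compound 2 (0.24 log units; within the scatter) and it exchanges a group at the same place. Compound 3 `O=C(O)c1ccc2c(CN3CCC[C@H](O[C@H](CO)c4cc(Cl)cc(Cl)c4)[C@@H]3c3ccccc3)c[nH]c2c1` differs from compound 2 by a group of 12 heavy atoms (9 carbon, 1 nitrogen, 2 oxygen; one five-membered aromatic ring with 1 hetero atom, one six-membered aromatic ring of carbon only) in place of a group of 9 heavy atoms (6 carbon, 2 nitrogen, 1 oxygen; one five-membered aromatic ring with 3 hetero atoms, one six-membered aromatic ring of carbon only), on a saturated chain carbon bound to an amine nitrogen in a ring and the entering group is 6-carboxy-1H-indol-3-yl. For the measured compounds named here, no measured compound carries this group, so the earlier step is a poor guide to the new one. Starting from compound 2 at 11 10^-6 cm/s a lower number in this assay beyond the scatter is nevertheless expected, on the structural change alone. The expected change is a 5.5-fold lower number from compound 2 to compound 3 (0.74 log units; beyond the scatter) in this estimate. Compound 3 is estimated at 2 10^-6 cm/s with an expected range from 0.6 10^-6 cm/s to 6 10^-6 cm/s in this measure.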

Compound 3, apparent permeability: 4 10^-6 cm/s
Compound 3: the middle estimate sits 2.0-fold (0.30 log units) below what was measured, and the stated range covers the measured number.
By their numbers in this assay, from the lowest: compound 3; then compounds 2 and 1 (each within the scatter of the next).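

In this assay the place on a saturated chain carbon bound to an amine nitrogen in a ring now gives a step beyond the scatter: 6-carboxy-1H-indol-3-yl brings a 2.8-fold lower number from compound 2 to compound 3 (0.44 log units; beyond the scatter) and a 4.8-fold lower number from compound 1 to compound 3 (0.68 log units; beyond the scatter) as well. Among the compounds shown here, the only earlier exchange here, a 1.7-fold lower number from compound 1 to compound 2 (0.24 log units; within the scatter), stayed within the scatter, so the number at this place does respond to the group it carries, and compound 3 stands apart from the other two. Nothing given here bears on why the number falls with this group.

The compounds shown leave open whether the fall belongs to the carboxy group or to the indole ring that carries it, since both enter together. A plain 1H-indol-3-yl group, or a methyl ester in place of the carboxylic acid, on the same carbon would separate the two.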